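Swapping Naphthalen-1-yl for Phenoxy: Expected Solubility

The compounds below may be only part of what the source reports. "The series", "measured", "known", "first", "only" and "open" are said of these compounds alone.

Measured so far:
compound 1 `c1ccc(Oc2ccc3c(NCCCNCc4ccco4)ccnc3c2)cc1`: 14500 nM
compound 2 `COc1ccc(F)cc1CNCCCNc1ccnc2cc(-c3cccc4ccccc34)ccc12`: 32000 nM

Both numbers come from a physicochemical assay for solubility, with a stated time of 18 h, at pH 7.4; on this read-out higher numbers stand for higher solubility and lower numbers for lower solubility. Compound 2 stands highest of the two; its nearest neighbour is compound 1, and the gap between them lies beyond the usual scatter.

Compound 3 `COc1ccc(F)cc1CNCCCNc1ccnc2cc(Oc3ccccc3)ccc12` is compound 2 with one change: phenoxy in place of naphthalen-1-yl on an aromatic carbon. Going by the values given here, no measured pair shows this same change, so the size of the step is uncertain. A small rise in this assay is expected, a 1.4-fold higher number from compound 2 to compound 3 (0.15 log units; within the scatter), possibly still within the scatter. Compound 3 is therefore estimated at 45000 nM, with a range from 15000 nM to 130000 nM.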

Compound 3, solubility: 14500 nM
For compound 3 the middle estimate is 3.1-fold (0.49 log units) above the measured one; measured number outside the range, below it.
By their numbers in this assay, from the lowest: compounds 1 and 3 (each within the scatter of the next); then compound 2.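

In this assay, phenoxy in place of naphthalen-1-yl on this aromatic carbon gives a 2.2-fold lower number from compound 2 to compound 3 (0.34 log units; beyond the scatter) and so lowers the number by a modest step. With phenoxy held fixed, 5-fluoro-2-methoxyphenyl in place of furan-2-yl on the saturated chain carbon gives no change at the digits printed from compound 1 to compound 3 (within the scatter) and so leaves the read-out unmoved. Nothing available explains either result. Still open, as far as these compounds go, is whether the phenoxy step repeats with furan-2-yl on the chain, and how a morpholine or a carboxylic acid on that aromatic carbon would read.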